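Replacing a conjugated aldehyde side chain with an ester

The source may report more compounds than this note shows. Statements on the series, on what has been measured and on what is new or still open speak of the compounds shown alone.

Compound 1 `Cc1cc(O)cc(O)c1C(=O)O[C@H]1[C@@H]2COC(/C=C/[C@H](C)O)=CC2=CC(=O)[C@@]1(C)O` — 78600 nM
Compound 2 `Cc1cc(O)cc(O)c1C(=O)O[C@H]1[C@@H]2COC(/C=C/C=O)=CC2=CC(=O)[C@@]1(C)O` — 22900 nM

Both numbers come from an assay on isolated protein for inhibition of Alpha glucosidase (Homo sapiens), read by spectrophotometry, with stated times of 20 min and 1 min; a lower number here means a stronger inhibitor, a higher number a weaker inhibitor. Compound 2 has the lower of the two numbers, and the step of a 3.4-fold lower number from compound 1 to compound 2 (0.54 log units; beyond the scatter) separates it from compound 1.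

Compound 3 `COC(=O)CCC1=CC2=CC(=O)[C@@](C)(O)[C@@H](OC(=O)c3c(C)cc(O)cc3O)[C@@H]2CO1` has not yet been measured. It differs from compound 2 in one place: 2-(methoxycarbonyl)ethyl in place of 2-formylethenyl on a double-bonded ring carbon. Going by the values given here, the only measured step touches this same side chain, where a 3.4-fold lower number from compound 1 to compound 2 (0.54 log units; beyond the scatter) accompanied a change at its far end. Compound 3 goes further, removing the formyl group and the double bond that carried it and putting in an ester, so the gain seen on going to the formyl group may not carry over. A modest step back toward the number of compound 1 is expected, a 2.2-fold higher number from compound 2 to compound 3 (0.34 log units; beyond the scatter), giving an estimate for compound 3 of 50000 nM in this assay, with a likely range from 15000 nM to 160000 nM.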

Compound 3, half-maximal inhibitory concentration: > 200000 nM
Compound 3: no number, only a limit; the forecaster's own chance of this, stated with the estimate: 10%; middle value at least 4.0-fold (0.60 log units) away from the limit.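

At this position, the side chain can do more than shift the number modestly. In this assay, going by these compounds alone, replacing the side chain gives an at least 8.7-fold higher number from compound 2 to compound 3 (0.94 log units; beyond the scatter) and also an at least 2.5-fold higher number from compound 1 to compound 3 (0.40 log units; beyond the scatter), so the 2-(methoxycarbonyl)ethyl chain falls behind both chains that keep a double bond, not only the one ending in formyl. Compound 3 gives only a limit of the assay, not a number, so both steps are minimum sizes: the limit of > 200000 nM in this assay, at which 1 of the 3 values shown sits.

This change removes the chain double bond and replaces the formyl group with an ester in one step, and the compounds shown do not separate these two changes. Also open, as far as these compounds go, is how a carboxylic acid or an amide at the end of the same chain would compare, with or without the double bond.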